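Methyl to methoxy on the outer phenyl ring

A few compounds are considered here, and "the series" means these few. Any claim that something is new, unique, unknown or untested is made for them only; others in the source may bear on it.

Of the compounds shown here, two that share one core have been measured in a functional assay on A549 cells (Homo sapiens) for antiproliferative activity, read by MTT assay, with a stated time of 48 h, in the presence of a further agent that is not named here; a lower number here means a stronger inhibitor of growth, a higher number a weaker inhibitor of growth. Compound 1 `O=C(NOCc1ccccc1)c1cn(-c2ccccc2)nc1-c1ccccc1` carries an unsubstituted phenyl ring at the position under study, and in this assay compound 1 gives 5000 nM. Compound 2 `Cc1ccc(-c2nn(-c3ccccc3)cc2C(=O)NOCc2ccccc2)cc1` differs only by a methyl in place of hydrogen on an aromatic carbon, and in this assay compound 2 gives 1140 nM. Going by the values given here, that single change produced a 4.4-fold lower number from compound 1 to compound 2 (0.64 log units; beyond the scatter), so compound 2 stands lowest of the two numbers measured, with compound 1 as its only neighbour.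

Compound 3 `COc1ccc(-c2nn(-c3ccccc3)cc2C(=O)NOCc2ccccc2)cc1` takes one further step: methoxy in place of methyl on an aromatic carbon. Among the compounds with values here, the only measured step that touches this aromatic carbon is a 4.4-fold lower number from compound 1 to compound 2 (0.64 log units; beyond the scatter), which compares hydrogen with methyl rather than methyl with methoxy, so it offers limited guidance. Nothing measured here separates one small substituent from another at this place, and no step beyond the scatter is expected. Compound 3 is expected to give 1200 nM, within a range of 400 nM to 3600 nM. The expected step is therefore a 1.1-fold higher number from compound 2 to compound 3 (0.02 log units; within the scatter).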

Compound 3, concentration for 50% growth inhibition: 1940 nM
The estimate for compound 3 lay 1.6-fold (0.21 log units) below the measured number; low and high end bracket the measured number.
By their numbers in this assay, from the lowest: compounds 2 and 3 (each within the scatter of the next); then compound 1.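

In this assay, methoxy in place of methyl gives a 1.7-fold higher number from compound 2 to compound 3 (0.23 log units; within the scatter) and so does not separate the two groups at this place, even though methoxy brings an oxygen and a hydrogen-bond acceptor that methyl lacks. Hydrogen now has two substituted comparisons rather than one: beside a 4.4-fold lower number from compound 1 to compound 2 (0.64 log units; beyond the scatter) stands a 2.6-fold lower number from compound 1 to compound 3 (0.41 log units; beyond the scatter) and both point the same way, so for these three compounds, a methyl or methoxy group at this place goes with a lower number than hydrogen, by a step beyond the scatter. No measured evidence here accounts for the change from hydrogen or for the closeness of methyl and methoxy.

Going by these compounds, it remains open whether this place would respond differently to a group of another kind, such as an amine, a carboxylic acid, a chlorine atom or a longer chain such as butoxy. Also open, on these data alone, is whether the same substituents would give a similar result on the other phenyl ring of the shared core, or in a different assay.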